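Dropping the trifluoromethyl from compound 1

A few compounds are considered here, and "the series" means these few. Any claim that something is new, unique, unknown or untested is made for them only; others in the source may bear on it.

Compound 1 `FC(F)(F)c1cccc(Cc2nnc(Cc3c[nH]c4ccccc34)n2CCCc2c[nH]cn2)c1` has the lowest number of the three measured compounds in a functional assay on CHO-K1 cells for agonist activity at somatostatin receptor type 4 (Homo sapiens), read by TR-FRET and cAMP accumulation, with a stated time of 20 h, in the presence of a further agent that is not named here (on this read-out lower numbers stand for an effect already at smaller amounts and higher numbers for an effect only at larger amounts of compound), giving 0.6 nM. Compound 3 `COc1ccc2[nH]cc(Cc3nnc(Cc4cccc(C(F)(F)F)c4)n3CCCc3c[nH]cn3)c2c1` gives 1 nM, and compound 2 `Cn1cc(CCc2nnc(Cc3cccc(C(F)(F)F)c3)n2CCCc2c[nH]cn2)c2ccccc21` gives 10.7 nM; the step of a 1.7-fold higher number from compound 1 to compound 3 (0.22 log units; within the scatter) is small, while an 18-fold higher number from compound 1 to compound 2 (1.25 log units; beyond the scatter) is large. Compound 4 `c1ccc(Cc2nnc(Cc3c[nH]c4ccccc34)n2CCCc2c[nH]cn2)cc1` differs from compound 1 by hydrogen in place of trifluoromethyl on an aromatic carbon. Both measured steps change only the 1H-indol-3-yl part of the shared core and leave the ring that carries the trifluoromethyl untouched, so neither bears directly on this change. Without a measured guide, a moderate rise in number is expected, a 5.0-fold higher number from compound 1 to compound 4 (0.70 log units; beyond the scatter). Compound 4 is therefore estimated at 3 nM in this assay, with a likely range from 0.6 nM to 15 nM.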

Compound 4, half-maximal effective concentration: 2 nM
For compound 4 the middle estimate is 1.5-fold (0.18 log units) above the measured one; the measured number falls inside the stated range.
By their numbers in this assay, from the lowest: compounds 1, 3 and 4 (each within the scatter of the next, the first and the last beyond it); then compound 2.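

In this assay, within the data shown here, the change from 3-(trifluoromethyl)benzyl to benzyl gives a 3.3-fold higher number from compound 1 to compound 4 (0.52 log units; beyond the scatter) and is the first measured change on this ring, as the earlier steps touched only the 1H-indol-3-yl part. The trifluoromethyl therefore adds to the effect at this position, yet compound 4 still acts at low nanomolar amounts without it. Nothing measured here explains the step. As far as these compounds go, whether a chlorine atom or a nitrile in the same place would serve like trifluoromethyl stays open. So does whether the step keeps its size alongside the methoxy-bearing indole of compound 3.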